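The source may hold more compounds than are shown below. What is called first, only, known or untested is meant among the compounds shown, and "the series" means these compounds.

Measured so far in a physicochemical assay for solubility, read by HPLC; a lower number here means a less soluble compound, a higher number a more soluble compound: compound 1 `CCC(C)C(=O)N1CCN(c2nc(=O)c3cc(C(F)(F)F)cc([N+](=O)[O-])c3s2)CC1` gives 104 ug/mL; compound 2 `O=C(C1CCCC1)N1CCN(c2nc(=O)c3cc(C(F)(F)F)cc([N+](=O)[O-])c3s2)CC1` gives 5.34 ug/mL; compound 3 `O=C(C1CCC1)N1CCN(c2nc(=O)c3cc(C(F)(F)F)cc([N+](=O)[O-])c3s2)CC1` gives 39.3 ug/mL.

Compound 3 stands second highest of the three numbers. Its nearest neighbour is compound 1, separated by a 2.6-fold lower number from compound 1 to compound 3 (0.42 log units; beyond the scatter); its furthest is compound 2, separated by a 7.4-fold higher number from compound 2 to compound 3 (0.87 log units; beyond the scatter).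

Compound 4 `CC(C)(C)C1CCC(C(=O)N2CCN(c3nc(=O)c4cc(C(F)(F)F)cc([N+](=O)[O-])c4s3)CC2)CC1` differs from compound 3 in one place: 4-(tert-butyl)cyclohexyl in place of cyclobutyl on a carbonyl carbon. All three measured steps bear on this position. Going from sec-butyl to cyclopentyl gave a 19-fold lower number from compound 1 to compound 2 (1.29 log units; beyond the scatter), from sec-butyl to cyclobutyl gave a 2.6-fold lower number from compound 1 to compound 3 (0.42 log units; beyond the scatter), and from cyclopentyl to cyclobutyl gave a 7.4-fold higher number from compound 2 to compound 3 (0.87 log units; beyond the scatter). The reverse of that last step, cyclobutyl to a five-membered ring, already lowered the number substantially, and the group entering in compound 4 goes further still, to a six-membered ring carrying a tert-butyl group. A large drop in this assay is therefore expected, a 66-fold lower number from compound 3 to compound 4 (1.82 log units; beyond the scatter), and compound 4 is estimated at 0.6 ug/mL, with a range from 0.1 ug/mL to 3 ug/mL.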

Compound 4, solubility: < 0.1 ug/mL
Compound 4 was reported as a limit (the forecaster's own chance of this, stated with the estimate: 30%); at least 6.0-fold (0.77 log units) between middle value and limit.
By their numbers in this assay, from the lowest: compound 2; then compound 3; then compound 1. At a limit, below all of these: compound 4.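

In this assay compound 4 is reported as a limit and not as a number, so its steps give only a minimum size: the limit of < 0.1 ug/mL in this assay, at which 1 of the 4 values shown sits. At this position on a carbonyl carbon, 4-(tert-butyl)cyclohexyl gives an at least 390-fold lower number from compound 3 to compound 4 (2.59 log units; beyond the scatter), an at least 53-fold lower number from compound 2 to compound 4 (1.72 log units; beyond the scatter) and an at least 1000-fold lower number from compound 1 to compound 4 (3.01 log units; beyond the scatter), all large and beyond the scatter. Compounds 1, 2 and 3 all gave readable numbers, so this is the only change shown that takes the read-out beyond what the assay reports as a number.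

How far compound 4 lies past its limit stays open, and its group differs from the others in both ring size and the tert-butyl group, which the compounds shown do not separate. Nor do they show how a plain cyclohexyl, or a cyclohexyl carrying an amine or a carboxylic acid, would read here.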